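The source may report more compounds than this note shows. Statements on the series, on what has been measured and on what is new or still open speak of the compounds shown alone.

Measured so far:
- compound 1 `Cc1ccc(-c2cs/c(=N/NC(=O)CSc3nnnn3-c3ccccc3)n2-c2ccccc2)cc1`: 66.8%
- compound 2 `O=C(CSc1ncccn1)N/N=c1/scc(-c2ccc(Br)cc2)n1-c1ccccc1`: 76.4%

In a functional assay on C6 cells (Rattus norvegicus) for cytotoxicity, read by MTT assay, with a stated time of 24 h, tested at 6 ug/mL (a higher number here means a weaker effect of the compound at the concentration tested, a lower number a stronger effect), compound 2 gives 76.4%, the highest of the two numbers, while compound 1 gives 66.8%, a gap within the scatter. Compound 3 `Cc1ccc(-c2cs/c(=N/NC(=O)CSc3ncccn3)n2-c2ccccc2)cc1` awaits measurement. It differs from compound 2 in one place: methyl in place of bromo on an aromatic carbon, so 4-bromophenyl becomes 4-methylphenyl. Among the measured compounds shown here, no step between measured compounds is available, so the effect of this change is unknown; compound 1, which also carries the methyl, sits within the scatter of compound 2. Compound 3 is therefore expected to move by a number 4.4 percentage points lower from compound 2 to compound 3 (within the scatter), nothing beyond the scatter. Compound 3 is estimated at 72%, between 58% and 86%.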

Compound 3, a percentage reported as activity, at one concentration (the size of the read-out at that concentration, not a potency): 93.2%
Compound 3: middle estimate off by 21.2 percentage points, on the low side, and the stated range ends below it.
By their numbers in this assay, from the lowest: compounds 1 and 2 (each within the scatter of the next); then compound 3.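

In this assay, methyl in place of bromo gives a number 16.8 percentage points higher from compound 2 to compound 3 (beyond the scatter), so this aromatic carbon, para to a large group, matters to the read-out, with the methyl giving the weaker effect. With the methyl held, pyrimidin-2-yl in place of 1-phenyl-1H-tetrazol-5-yl on the sulfur gives a number 26.4 percentage points higher from compound 1 to compound 3 (beyond the scatter), so the group on the sulfur matters too. Nothing at hand explains either step.

On these data alone, it remains open how a chloro, a methoxy or an amine at this position would read. As far as these compounds go, it is also open whether methyl in place of bromo gives a similar step with 1-phenyl-1H-tetrazol-5-yl on the sulfur.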